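Halogen swap on the benzyl group: chloro to fluoro

The source may report more compounds than this note shows. Statements on the series, on what has been measured and on what is new or still open speak of the compounds shown alone.

Among the measured compounds shown here, compound 2 `CNc1nc(-c2ccccc2)nc2c1nnn2Cc1ccccc1Cl` stands at 191 nM in an assay on Cerebral cortex for displacement of a labelled ligand from adenosine receptor A1 (Bos taurus) (a lower number here means a stronger inhibitor, a higher number a weaker inhibitor), and its only neighbour so far is compound 1 `CNc1nc(-c2ccccc2)nc2c1nnn2Cc1ccccc1` at 353 nM, the gap between the two lying within the scatter. Compound 3 `CNc1nc(-c2ccccc2)nc2c1nnn2Cc1ccccc1F` differs from compound 2 by fluoro in place of chloro on an aromatic carbon. For the measured compounds named here, the single measured step that bears on this exchange is a 1.8-fold lower number from compound 1 to compound 2 (0.27 log units; within the scatter), the arrival of the chloro that now leaves, and it stayed within the scatter. Replacing one halogen with another at a site where the first halogen itself moved the number so little gives no ground to expect a shift beyond the scatter in either direction. Compound 3 is therefore expected to give about 250 nM in this assay, with a range from 120 nM to 520 nM. The step this estimate implies is a 1.3-fold higher number from compound 2 to compound 3 (0.12 log units; within the scatter), expected to remain within the scatter.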

Compound 3, inhibition constant: 25 nM
Beside the measured number, compound 3's estimate is 10-fold (1.00 log units) above it, outside the stated range (below it).
By their numbers in this assay, from the lowest: compound 3; then compounds 2 and 1 (each within the scatter of the next).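

In this assay, exchanging 2-chlorobenzyl for 2-fluorobenzyl gives a 7.6-fold lower number from compound 2 to compound 3 (0.88 log units; beyond the scatter), so this aromatic carbon, ortho to a large group, responds to which halogen it carries. Fluoro in place of hydrogen gives a 14-fold lower number from compound 1 to compound 3 (1.15 log units; beyond the scatter), whereas chloro in place of hydrogen gave only a 1.8-fold lower number from compound 1 to compound 2 (0.27 log units; within the scatter); the near-silent chloro step had therefore hidden that a single-atom change at this carbon can move the number well beyond the scatter. Nothing available accounts for the gap between the two halogens.

Going by these compounds, whether a bromo, a methyl or a methoxy at this carbon would track with fluoro or with chloro remains open. Also open, on these data alone, is whether fluoro on another carbon of this ring, or on the phenyl group of the shared core, gives a step of similar size.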